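The source may hold more compounds than are shown below. What is called first, only, known or untested is meant among the compounds shown, and "the series" means these compounds.

Compound 1 `Oc1cccc2c1nc(-c1c(F)cccc1F)n2Cc1c(F)cccc1F`: > 100 uM (a limit of the assay, not a number)
Compound 2 `Fc1cccc(F)c1Cn1c(-c2c(F)cccc2F)nc2c(Cl)cccc21`: 30.4 uM
Compound 3 `CC(=O)Nc1cccc2c1nc(-c1c(F)cccc1F)n2Cc1c(F)cccc1F`: 39.3 uM

In a toxicity assay on CCRF-CEM cells (Homo sapiens) for cytotoxicity (on this read-out higher numbers stand for lower toxicity in this test and lower numbers for higher toxicity in this test), compound 3 gives 39.3 uM, level with compound 2, since the measured change is a 1.3-fold higher number from compound 2 to compound 3 (0.11 log units; within the scatter). Compound 1 stands apart, with an at least 2.5-fold lower number from compound 1 to compound 3 (0.40 log units; beyond the scatter).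

Compound 4 `CC(=O)N(C)c1cccc2c1nc(-c1c(F)cccc1F)n2Cc1c(F)cccc1F` carries methyl in place of hydrogen on an amide-type nitrogen. Among the measured compounds shown here, no measured step alters that nitrogen. For the measured compounds named here, the closest guides are the two exchanges of the whole acetamido group, and the one from compound 2 stayed small, at a 1.3-fold higher number from compound 2 to compound 3 (0.11 log units; within the scatter). No step beyond the scatter is therefore expected, in either direction. The expected change is a 1.0-fold higher number from compound 3 to compound 4 (0.01 log units; within the scatter). The estimate for compound 4 is 40 uM, with an expected range of 16 uM to 100 uM.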

Compound 4, half-maximal toxic concentration: > 100 uM
Compound 4 gave a limit, no number; the forecaster's own chance of this, stated with the estimate: 15%; middle value at least 2.5-fold (0.39 log units) away from the limit.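

In this assay compound 4 gives > 100 uM, a limit of the assay and not a number: the limit of > 100 uM in this assay, at which 2 of the 4 values shown sit. The amide-type nitrogen proves to be a sensitive place, for methyl in place of the amide hydrogen gives an at least 2.5-fold higher number from compound 3 to compound 4 (0.40 log units; beyond the scatter), a step beyond the scatter, though acetamido in place of chloro had stayed within it. Measured against chloro, the acetyl(methyl)amino group gives an at least 3.2-fold higher number from compound 2 to compound 4 (0.51 log units; beyond the scatter). The step from compound 1 to compound 4 cannot be read, both values being limits. Also open, as far as these compounds go, is whether an ethyl group on that nitrogen would give the same result.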